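Lengthening the linker of a hydroxamic acid aminopyrimidine

The source may hold more compounds than are shown below. What is called first, only, known or untested is meant among the compounds shown, and "the series" means these compounds.

Compound 1 `O=C(CCCCCn1cc(Nc2ncc(Cl)c(Nc3ccccc3Cl)n2)cn1)NO` carries a hydroxycarbamoyl group at the end of a saturated chain attached to an aromatic nitrogen. In a functional assay on K562 cells (Homo sapiens) for antiproliferative activity, read by MTT assay, with a stated time of 48 h (a lower number here means a stronger inhibitor, a higher number a weaker inhibitor), compound 1 gives 1810 nM. Two related compounds, which share the core but differ in the halogen pattern of the aryl groups, have also been measured: compound 2 `O=C(CCCCCCn1cc(Nc2ncc(Cl)c(Nc3ccc(Cl)cc3)n2)cn1)NO` gives 320 nM in this assay, and compound 3 `O=C(CCCCCCn1cc(Nc2ncc(C(F)(F)F)c(Nc3ccc(F)cc3)n2)cn1)NO` gives 480 nM. Of the three, compound 1 has the highest number, so it is the weakest inhibitor; compound 3 is nearest to it and compound 2 furthest, and both gaps lie beyond the usual scatter.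

Compound 4 `O=C(CCCCCCn1cc(Nc2ncc(Cl)c(Nc3ccccc3Cl)n2)cn1)NO` differs from compound 1 in one place: (hydroxycarbamoyl)methyl in place of hydroxycarbamoyl on a saturated chain carbon, five bonds along the chain from an aromatic nitrogen. Compounds 2 and 3, whose numbers are lower than that of compound 1, also carry the (hydroxycarbamoyl)methyl end on the chain, but they differ from compound 1 in the aryl groups as well, so their values do not isolate the effect of the chain alone.

The author expects the step of a 3.0-fold lower number from compound 1 to compound 4 (0.48 log units; beyond the scatter) to be downward and to exceed the scatter, with the number for compound 4 moving toward those of compounds 2 and 3. Compound 4 is estimated at 600 nM, within 250 nM to 1500 nM.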

Compound 4, half-maximal inhibitory concentration: 860 nM
Compound 4: middle estimate off by 1.4-fold (0.16 log units), on the low side; the range from low to high includes it.
By their numbers in this assay, from the lowest: compounds 2, 3 and 4 (each within the scatter of the next, the first and the last beyond it); then compound 1.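

With the aryl groups unchanged, the step at this chain carbon can now be read on its own: (hydroxycarbamoyl)methyl in place of hydroxycarbamoyl gives, in this assay, a 2.1-fold lower number from compound 1 to compound 4 (0.32 log units; beyond the scatter), a modest change beyond the scatter that compounds 2 and 3 could not isolate. Among these compounds, compound 4 also gives the first clean reading of the aryl group on this longer chain, since 2-chlorophenyl in place of 4-chlorophenyl on a nitrogen on an aromatic ring gives a 2.7-fold higher number from compound 2 to compound 4 (0.43 log units; beyond the scatter), likewise modest and beyond the scatter, so the chain end and the aryl group each move the number independently of the other. No measurement among the data shown accounts for either step.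

On these data alone, it remains open whether a further extension to 2-(hydroxycarbamoyl)ethyl at this carbon would carry the number lower or reverse the direction, and whether a carboxylic acid at the chain end would retain any antiproliferative activity. The chain step is also known here only with the 2-chlorophenyl group, so whether it holds with 4-chlorophenyl stays unsettled.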